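Aryl swaps on the shared core and maximal response

The compounds below may be only part of what the source reports. "The series", "measured", "known", "first", "only" and "open" are said of these compounds alone.

Compound 3 `O=C(O)Cc1sc(C(c2ccc(F)cc2)c2ccc(F)cc2)nc1-c1cccc(F)c1` gives 80% in an in vitro functional assay on HEK285-7 cells for antagonist activity at prostaglandin D2 receptor 2 (Homo sapiens), read by BRET and beta-arrestin recruitment; on this read-out lower numbers stand for smaller maximal responses and higher numbers for larger maximal responses. Compound 1 `O=C(O)Cc1sc(C(c2ccc(F)cc2)c2ccc(F)cc2)nc1-c1ccnc(N2CCCC2)c1` gives 80% and compound 2 `CS(=O)(=O)Nc1cccc(-c2nc(C(c3ccc(F)cc3)c3ccc(F)cc3)sc2CC(=O)O)c1` gives 80%; compound 3 is level with both, since no change at the digits printed from compound 1 to compound 3 (within the scatter) and no change at the digits printed from compound 2 to compound 3 (within the scatter) lie within the scatter, as does no change at the digits printed from compound 1 to compound 2 (within the scatter). Compound 4 `Nc1cc(-c2nc(C(c3ccc(F)cc3)c3ccc(F)cc3)sc2CC(=O)O)cc(F)n1` is not yet measured; it differs from compound 3 by 2-amino-6-fluoropyridin-4-yl in place of 3-fluorophenyl on an aromatic carbon. All three measured steps exchange this same aryl group, among 2-(pyrrolidin-1-yl)pyridin-4-yl, 3-(methanesulfonamido)phenyl and 3-fluorophenyl, and none moved the maximal response beyond the scatter. The 2-amino-6-fluoropyridin-4-yl entering here is another such exchange, so no step beyond the scatter is expected in this assay, no change at the digits printed from compound 3 to compound 4 (within the scatter). Compound 4 is therefore estimated at 80%, between 70% and 90%.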

Compound 4, largest response reached (reported as efficacy), in percent of the reference or control that the assay uses: 30%
Beside the measured number, compound 4's estimate is 50 percentage points above it, outside the stated range (below it).
By their numbers in this assay, from the lowest: compound 4; then compounds 1, 2 and 3 (each within the scatter of the next).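

In this assay, going by these compounds alone, the aryl position next to the ring nitrogen is not indifferent to exchange, since 2-amino-6-fluoropyridin-4-yl gives a number 50 percentage points lower from compound 3 to compound 4 (beyond the scatter) and a number 50 percentage points lower from compound 2 to compound 4 (beyond the scatter) and a number 50 percentage points lower from compound 1 to compound 4 (beyond the scatter) in the first steps here beyond the scatter. Compound 1 also carries a pyridin-4-yl group and stays level with compounds 2 and 3, so that ring alone does not go with the lower response. Nothing at hand bears on why the response falls with this exchange. Which of the amino and fluoro substituents goes with the lower response stays open, as 2-aminopyridin-4-yl and 2-fluoropyridin-4-yl do not appear among these compounds. A methylamino group or a hydroxyl in place of the amino group is equally untested here.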